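This account rests on a few compounds, and the source may have more. Where it says the series, first, only, none or still open, it means among the compounds named here.

Compound 1 `O=C(/C(=C/C1CCCCC1)CCl)c1ccccc1` — 30000 nM
Compound 2 `O=C(/C(=C/c1ccccc1)CCl)c1ccccc1` — 23000 nM

Among the compounds with values here, in a functional assay on HeLa cells (Homo sapiens) for inhibition, read by sulforhodamine B assay, with a stated time of 48 h (on this read-out lower numbers stand for stronger inhibition of growth and higher numbers for weaker inhibition of growth), compound 2 gives the lowest of the two numbers so far, though the only step measured, a 1.3-fold lower number from compound 1 to compound 2 (0.12 log units; within the scatter), lies within the scatter, so no order between the two is established. Compound 3 `O=C(/C(=C/c1ccc(Cl)cc1)CCl)c1ccccc1` differs from compound 2 by chloro in place of hydrogen on an aromatic carbon. Within the data shown here, no measured step bears on this change: a 1.3-fold lower number from compound 1 to compound 2 (0.12 log units; within the scatter) concerns a different part of the molecule and is itself within the scatter. For compound 3 a step of a 1.2-fold lower number from compound 2 to compound 3 (0.06 log units; within the scatter) is therefore expected, nothing beyond the scatter. Compound 3 is estimated at 20000 nM, range 7000 nM to 60000 nM.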

Compound 3, concentration for 50% growth inhibition: 22000 nM
The estimate for compound 3 lay 1.1-fold (0.04 log units) below the measured number; the measured number falls inside the stated range.
By their numbers in this assay, from the lowest: compounds 3, 2 and 1 (each within the scatter of the next).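

Chloro in place of hydrogen on an aromatic carbon, para to a large group, gives in this assay a 1.0-fold lower number from compound 2 to compound 3 (0.02 log units; within the scatter). Within the data shown here, the earlier compounds carried no substituent on this ring, so this is the first reading at this position: in this assay, the chlorine atom brings no shift beyond the scatter. No measurement at hand offers an explanation for this result.

From the compounds shown here alone, whether an amine or a carboxylic acid at this position would give a number beyond the scatter remains open. The same holds for a longer chain in place of chloro.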